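From methoxy to hydroxy at a cytotoxicity limit

The source may report more compounds than this note shows. Statements on the series, on what has been measured and on what is new or still open speak of the compounds shown alone.

In an ADME assay on cells (Fibroblast, Homo sapiens) for cytotoxicity, with a stated time of 48 h (on this read-out lower numbers stand for stronger inhibition and higher numbers for weaker inhibition), compound 1 (`COc1cc(OC)c(C(=O)/C=C/c2ccccc2SC)c(OC)c1`) gives > 20000 nM, which is a limit of the assay and not a number. Compound 2 (`COc1cccc(/C=C/C(=O)c2c(OC)cc(OC)cc2OC)c1`) also reports only a limit, > 20000 nM. Compound 3 (`COc1cc(OC)c(C(=O)/C=C/c2ccc(Br)cc2)c(OC)c1`) likewise reports only a limit, > 20000 nM. The whole set therefore sits at the limit of > 20000 nM in this assay, at which 3 of the 3 values shown sit, and compound 1 has no number to anchor a comparison.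

Compound 4 (`COc1cc(O)c(C(=O)/C=C/c2ccccc2SC)c(OC)c1`) departs from compound 1 in one place, with hydrogen in place of methyl on an oxygen on an aromatic ring, methoxy to hydroxy: hydrogen in place of methyl on an oxygen on an aromatic ring.

The measured steps offer little guidance. All three replace the group on a double-bonded chain carbon: a step that the two limits leave unreadable from compound 1 to compound 2, a step that the two limits leave unreadable from compound 1 to compound 3 and a step that the two limits leave unreadable from compound 2 to compound 3. None of them touches that oxygen, and none has a readable size. In this assay, the step expected on this thin basis is a step that the limit leaves unreadable from compound 1 to compound 4, which amounts to no expected change beyond the scatter, and the range is kept wide to allow a shift in either direction. For compound 4 the estimated value is 22000 nM, with an expected range from 8000 nM to 50000 nM.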

Compound 4, half-maximal inhibitory concentration: > 20000 nM
Compound 4 gave a limit, no number (the forecaster's own chance of this, stated with the estimate: 65%); the middle value is on the limit's open side.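

In this assay compound 4 gives > 20000 nM, which is a limit and not a number. The step between compound 1 and compound 4 therefore cannot be read, because both sit at the same limit: the limit of > 20000 nM in this assay, at which 4 of the 4 values shown sit.

The compounds shown leave open whether any change to the shared core would give a measurable value in this assay.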